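This account rests on a few compounds, and the source may have more. Where it says the series, first, only, none or still open, it means among the compounds named here.

Two compounds share one core and differ only in a single group on an aromatic ring. Compound 1 `C=CC[C@H]1C[C@]2([C@@H](C)Cc3cc(C#N)c(OC)cc3F)OCOC2=CC1=O` carries a cyano group there, and in a functional assay on NCI-H460 cells (Homo sapiens) for antiproliferative activity, with a stated time of 72 h (on this read-out higher numbers stand for weaker inhibition and lower numbers for stronger inhibition), compound 1 gives 150 nM. Compound 2 `C=CC[C@H]1C[C@]2([C@@H](C)Cc3cc(NC(C)=O)c(OC)cc3F)OCOC2=CC1=O` carries an acetamido group in the same place, and in this assay compound 2 gives 71 nM. Going by the values given here, that single exchange brought a 2.1-fold lower number from compound 1 to compound 2 (0.32 log units; beyond the scatter), so compound 2 stands as the lower of the two numbers measured so far, with compound 1 as its only neighbour.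

Compound 3 `C=CC[C@H]1C[C@]2([C@@H](C)Cc3ccc(OC)cc3F)OCOC2=CC1=O` takes the next step: hydrogen in place of acetamido on an aromatic carbon. Among the compounds with values here, no measured pair shows this exact removal; the only step available is the one from a cyano to an acetamido group, which was modest. Taking the group away altogether is a different change, so the direction is uncertain, and a number somewhat above that of compound 2 is expected, roughly the size of the step already seen. The expected step in this assay is a 2.1-fold higher number from compound 2 to compound 3 (0.32 log units; beyond the scatter). For compound 3 in this assay the estimate is 150 nM, in a range from 50 nM to 450 nM.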

Compound 3, half-maximal inhibitory concentration: 94 nM
Beside the measured number, compound 3's estimate is 1.6-fold (0.20 log units) above it; the range from low to high includes it.
By their numbers in this assay, from the lowest: compounds 2, 3 and 1 (each within the scatter of the next, the first and the last beyond it).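

Compound 3 carries only hydrogen on this aromatic carbon, ortho to a methoxy group and para to a fluoro group, so it shows what the position does with no added group at all. In this assay the removal of acetamido gives a 1.3-fold higher number from compound 2 to compound 3 (0.12 log units; within the scatter) and the exchange of cyano for hydrogen gives a 1.6-fold lower number from compound 1 to compound 3 (0.20 log units; within the scatter), so neither group can be said to change the number relative to plain hydrogen, and activity at this level does not depend on a substituent here; only the two substituted compounds lie beyond the scatter of each other, and by a modest step. Nothing measured on these compounds explains why the three numbers lie so close together.

From the compounds shown here alone, whether an amine, a carboxylic acid or a longer chain on this same carbon would stay this close to compound 3 remains open. Also open, going by these compounds, is whether replacing the methoxy group or the fluoro group on the same ring would matter more than the changes seen at this position.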